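This account rests on a few compounds, and the source may have more. Where it says the series, first, only, none or still open, it means among the compounds named here.

Among the measured compounds shown here, compound 2, `CNC(=O)c1cc(C(=O)N[C@@H]2C[C@H]2C)cc2c1O[C@H](CF)[C@H]2c1ccccc1`, holds the higher of the two numbers measured so far in a physicochemical assay for lipophilicity, at pH 7.4; a lower number here means a more polar compound, a higher number a more lipophilic compound: compound 2 gives 4.5. Compound 1, `CNC(=O)c1cc(C(=O)NC)c2c(c1)[C@](C)(c1ccccc1)CO2`, gives 3.4 in this assay, and the gap between these two values lies beyond the usual scatter of the measurement. Compound 3, `CNC(=O)c1cc(C(=O)NCCC[C@H]2OC[C@H](N)CO2)cc2c1O[C@H](CF)[C@H]2c1ccccc1`, has not yet been measured. It differs from compound 2 in a single place: a group of 10 heavy atoms (7 carbon, 1 nitrogen, 2 oxygen; one six-membered non-aromatic ring with 2 hetero atoms) in place of a group of 4 heavy atoms (4 carbon; one three-membered non-aromatic ring of carbon only), on an amide-type nitrogen. For the measured compounds named here, no measured pair of compounds shows this exchange, so there is no measured step to lean on, and the expectation rests on the change itself and on the value of compound 2. A fall in this assay is expected here, clearly beyond the scatter, with the step estimated at a number 2.20 log units lower from compound 2 to compound 3 (beyond the scatter). For compound 3 the expected value is 2.3, within a range from 1.5 to 3.2.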

Compound 3, distribution coefficient: 2.9
Compound 3: the middle estimate sits 0.60 log units below what was measured; low and high end bracket the measured number.
By their numbers in this assay, from the lowest: compound 3; then compound 1; then compound 2.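

Among the compounds shown here, this is the first measured step at this place: in this assay, exchanging 2-methylcyclopropyl on the amide-type nitrogen for the larger group with its six-membered non-aromatic ring gives a number 1.60 log units lower from compound 2 to compound 3 (beyond the scatter). The group on this nitrogen can therefore move the reading well past the usual scatter, and here the number falls even though the entering group has more heavy atoms, among them more carbon, and brings a hydrogen-bond donor and acceptors that 2-methylcyclopropyl lacks. Nothing measured here explains the fall.

The exchange alters size, ring, oxygen and nitrogen content all at once, so this single step cannot be shared out among those features. It also leaves open where a simple hydroxyl group or a carboxylic acid on this nitrogen, in place of the whole ring-bearing group, would fall in this assay.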